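Fluorophenyl regiochemistry on the pyridazinone amide series

The source may hold more compounds than are shown below. What is called first, only, known or untested is meant among the compounds shown, and "the series" means these compounds.

Measured so far:
compound 1 `Cc1cc(=O)n(-c2ccc(F)cc2)nc1C(=O)Nc1ccc(Oc2ncnc3ccsc23)c(F)c1` — 740 nM
compound 2 `Cc1cc(=O)n(-c2cccc(F)c2)nc1C(=O)Nc1ccc(Oc2ncnc3sccc23)c(F)c1` — 17300 nM

In a functional assay on MCF7 cells (Homo sapiens) for cytotoxicity, read by MTT assay, with a stated time of 72 h (on this read-out lower numbers stand for stronger inhibition and higher numbers for weaker inhibition), compound 1 gives 740 nM and compound 2 gives 17300 nM; compound 2 stands highest of the two numbers, with compound 1 the nearest at a lower value, a gap well beyond the scatter. Going by the values given here, the two structures differ in more than one place, so no single step is set out between them.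

Compound 3 `Cc1cc(=O)n(-c2ccc(F)cc2)nc1C(=O)Nc1ccc(Oc2ncnc3sccc23)c(F)c1` is the next case. It keeps the core of compound 2 and changes only the aryl on the ring nitrogen: 4-fluorophenyl in place of 3-fluorophenyl on an aromatic nitrogen. Going by these compounds, the change brings in the aryl that compound 1 carries, and with compound 1 at 740 nM a move toward lower numbers is expected, though how much of the gap between compound 1 and compound 2 this one change accounts for is unknown. The expected step from compound 2 to compound 3 is a 4.9-fold lower number from compound 2 to compound 3 (0.69 log units; beyond the scatter). Compound 3 is estimated at 3500 nM, within 700 nM to 17000 nM.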

Compound 3, half-maximal inhibitory concentration: 12300 nM
For compound 3 the middle estimate is 3.5-fold (0.55 log units) below the measured one; low and high end bracket the measured number.
By their numbers in this assay, from the lowest: compound 1; then compounds 3 and 2 (each within the scatter of the next).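

In this assay, 4-fluorophenyl in place of 3-fluorophenyl on the aromatic nitrogen gives a 1.4-fold lower number from compound 2 to compound 3 (0.15 log units; within the scatter), and on the core of compound 2 this position does not separate the two fluorophenyl groups. With 4-fluorophenyl held the same, exchanging the ring group on the oxygen on an aromatic ring gives a 17-fold higher number from compound 1 to compound 3 (1.22 log units; beyond the scatter), a large step and the first one shown at that place. No measured evidence at hand accounts for either step.

Whether the two fluorophenyl groups also stay within the scatter on the core of compound 1 remains open, as 3-fluorophenyl is shown only on the core of compound 2. Also open, going by these compounds, is how a different group on the aromatic nitrogen, such as unsubstituted phenyl or 4-methoxyphenyl, would read in this assay.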